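Removing the hydroxyalkyl branch from the amine nitrogen

The compounds below may be only part of what the source reports. "The series", "measured", "known", "first", "only" and "open" are said of these compounds alone.

Compound 3 `CC(C)N(CCN(C(=O)Nc1cc(Cl)nc(Cl)c1)C1CC[C@]2(c3cccc(C#N)c3)CC2C1)[C@@H](C)CO` gives 1.6 nM in a functional assay for antagonist activity at melanin-concentrating hormone receptor 1 (Homo sapiens) (a lower number here means a stronger inhibitor, a higher number a weaker inhibitor), the lowest of the three numbers shown. Compound 2 `CC(C)N(CCN(C(=O)Nc1cc(Cl)nc(Cl)c1)C1CC[C@]2(c3cccc(C#N)c3)CC2C1)C(C)C` gives 2.4 nM in this assay, and the step of a 1.5-fold lower number from compound 2 to compound 3 (0.18 log units; within the scatter) lies within the scatter. Compound 1 `CC(=O)NCc1cccc([C@]23CCC(N(CCN(C(C)C)C(C)C)C(=O)Nc4ccc(F)c(Cl)c4)CC2C3)c1` gives 31 nM in this assay, a number beyond the scatter from compound 3. Compound 4 `CC(C)NCCN(C(=O)Nc1cc(Cl)nc(Cl)c1)C1CC[C@]2(c3cccc(C#N)c3)CC2C1` differs from compound 3 by hydrogen in place of 1-(hydroxymethyl)ethyl on an amine nitrogen. Among the measured compounds shown here, the step of a 1.5-fold lower number from compound 2 to compound 3 (0.18 log units; within the scatter) is the only measured change on the amine side chain, and it stayed within the scatter; a removal of a whole group from this nitrogen has no measured counterpart, so only a modest step is expected. Compound 4 is therefore estimated at 4 nM, with a range of 1.5 nM to 12 nM in this assay. The expected step is a 2.5-fold higher number from compound 3 to compound 4 (0.40 log units; beyond the scatter).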

Compound 4, inhibition constant: 1.9 nM
For compound 4 the middle estimate is 2.1-fold (0.32 log units) above the measured one, within the range that was stated.
By their numbers in this assay, from the lowest: compounds 3, 4 and 2 (each within the scatter of the next); then compound 1.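

On the amine nitrogen, hydrogen can stand in place of the whole 1-(hydroxymethyl)ethyl group, with a 1.2-fold higher number from compound 3 to compound 4 (0.07 log units; within the scatter) in this assay. Hydrogen in place of isopropyl on the same nitrogen gives a 1.3-fold lower number from compound 2 to compound 4 (0.10 log units; within the scatter) in this assay. Both steps lie within the scatter, so on this core, compound 2, compound 3 and compound 4 show no need for either group at this position.

On these data alone, whether an acetyl group, a carboxylic acid or a longer chain on this nitrogen fits equally well stays open. No measured evidence explains why these steps are so small.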